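The compounds below may be only part of what the source reports. "The series", "measured", "known", "first", "only" and "open" are said of these compounds alone.

Working notes on the series in a functional assay on Hs 683 cells (Homo sapiens) for inhibition, read by MTT assay, with a stated time of 72 h; a higher number here means a weaker inhibitor of growth, a lower number a stronger inhibitor of growth. Compound 1 `CC1(C)CCC[C@]2(C)[C@@H](C=O)C(C=O)=CC[C@@H]12` carries formyl on a double-bonded ring carbon and gives 95000 nM. With 2-(methoxycarbonyl)ethenyl in that place, compound 2 `COC(=O)/C=C/C1=CC[C@H]2C(C)(C)CCC[C@]2(C)[C@H]1C=O` gives 24000 nM. The ester compound 3 `CCOC(=O)/C(C)=C/C1=CC[C@H]2C(C)(C)CCC[C@]2(C)[C@H]1C=O` gives 28000 nM. Compound 2 has the lowest number of the three, but its value lies within the scatter of compound 3, so the two cannot be separated. Only compound 1 stands clearly apart from compound 2.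

Compound 4 `CC1(C)CCC[C@]2(C)[C@@H](C=O)C(/C=C/C(=O)OCc3ccccc3)=CC[C@@H]12` keeps the shared core and changes only the ester of compound 2: phenyl in place of hydrogen on a saturated chain carbon bound to an oxygen next to a carbonyl group. This is the same as methoxy to benzyloxy. Going by the values given here, the one measured step, a 4.0-fold lower number from compound 1 to compound 2 (0.60 log units; beyond the scatter), concerns the replacement of formyl and says nothing direct about this change. Among the compounds with values here, no measured pair isolates phenyl in this place. The nearest evidence is compound 3, a different ester at 28000 nM, which remains within the scatter of compound 2. On that basis no large shift in this assay is anticipated, and no direction is favoured with confidence. The estimated step is a 1.2-fold lower number from compound 2 to compound 4 (0.08 log units; within the scatter), expected to remain within the scatter. For compound 4 the expected value is 20000 nM. The estimated range for compound 4 runs from 8000 nM to 48000 nM.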

Compound 4, concentration for 50% growth inhibition: 31000 nM
Compound 4: middle estimate off by 1.6-fold (0.19 log units), on the low side, and the stated range covers the measured number.
By their numbers in this assay, from the lowest: compounds 2, 3 and 4 (each within the scatter of the next); then compound 1.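

In this assay, going by these compounds alone, the step for phenyl in place of hydrogen on a saturated chain carbon bound to an oxygen next to a carbonyl group is a 1.3-fold higher number from compound 2 to compound 4 (0.11 log units; within the scatter) and it gives the first direct reading of this place, which no earlier pair isolated. Within the data shown here, the methoxy to benzyloxy change thus adds one six-membered aromatic ring of carbon only, with 6 heavy atoms, and produces no shift that can be told from the scatter, so at this place on the ester the series so far shows room for a much larger group with no measurable change in the number. Nothing measured here bears on why the step is this small.

Still open, from the compounds shown here alone, is whether a carboxylic acid or an amide in place of the ester would move the number beyond the scatter, since both compounds of this pair remain esters. Also open, going by these compounds, is whether a longer chain between the oxygen and the phenyl, or a chlorine or methoxy group on the phenyl, would leave the number as flat as this single step does.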